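The source may report more compounds than this note shows. Statements on the series, on what has been measured and on what is new or still open speak of the compounds shown alone.

Among the measured compounds shown here, compound 2 `O=C1c2c[n+]([O-])c3ccccc3c2C(=O)c2c1c1ccccc1n2Cc1cn(CC(O)CO)nn1` gives 440 nM in a functional assay on A-375 cells (Homo sapiens) for cytotoxicity, read by MTT assay, with a stated time of 72 h (on this read-out lower numbers stand for stronger inhibition and higher numbers for weaker inhibition), the highest of the three numbers measured so far. Compound 1 `O=C1c2c[n+]([O-])c3ccccc3c2C(=O)c2c1c1ccccc1n2Cc1cn(C[C@@H](O)CO)nn1` gives 140 nM; the step of a 3.1-fold higher number from compound 1 to compound 2 (0.50 log units; beyond the scatter) is modest, and the pair differ only in the fact that one of compounds 1 and 2 is drawn with a defined configuration and the other without, at the place where they differ. Compound 3 `O=C1c2c[n+]([O-])c3ccccc3c2C(=O)c2c1c1ccccc1n2CCN1CCCC1` gives 430 nM, and a 1.0-fold lower number from compound 2 to compound 3 (0.01 log units; within the scatter) lies within the scatter. Compound 4 `CC1(C)OC[C@H](Cn2cc(Cn3c4c(c5ccccc53)C(=O)c3c[n+]([O-])c5ccccc5c3C4=O)nn2)O1` alters the side chain of compound 2: 2,2-dimethyl-1,3-dioxolan-4-yl in place of 1,2-dihydroxyethyl on a saturated chain carbon bound to an aromatic nitrogen. For the measured compounds named here, no measured step exchanges the 1,2-dihydroxyethyl group for a 2,2-dimethyl-1,3-dioxolan-4-yl group, so nothing measured speaks to this change directly; the step from compound 2 to compound 3 shows only that the whole group on that carbon can be swapped with the number staying where it was. The step of a 1.1-fold higher number from compound 2 to compound 4 (0.06 log units; within the scatter) is therefore expected to be small. Compound 4 is estimated at 500 nM, with a range of 150 nM to 1600 nM.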

Compound 4, half-maximal inhibitory concentration: 180 nM
Estimate against measurement, compound 4: 2.8-fold (0.44 log units) above, within the range that was stated.
By their numbers in this assay, from the lowest: compounds 1 and 4 (each within the scatter of the next); then compounds 3 and 2 (each within the scatter of the next).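

The 2,2-dimethyl-1,3-dioxolan-4-yl group, with 0 hydrogen-bond donors against 2 in 1,2-dihydroxyethyl, is tolerated on this saturated chain carbon (a 2.4-fold lower number from compound 2 to compound 4 (0.39 log units; beyond the scatter)), so free hydroxyls are not required here. Against the diol with a defined configuration, the same exchange stays within the scatter (a 1.3-fold higher number from compound 1 to compound 4 (0.11 log units; within the scatter)), so the reading depends on which diol serves as reference. The two diols differ in one respect only: (the fact that one of compounds 1 and 2 is drawn with a defined configuration and the other without, at the place where they differ).

Still open, as far as these compounds go, is how the opposite configurations of compound 1 and compound 4 read. Also open, from the compounds shown here alone, is whether an amine or a carboxylic acid in place of these groups keeps the number.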